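Notes on the amide aryl group: compound 2 to compound 3

The compounds below may be only part of what the source reports. "The series", "measured", "known", "first", "only" and "open" are said of these compounds alone.

Compound 1 `CCn1cc(C(=O)Nc2ccccc2)c(=O)c2cc(F)c(N3CCNC(C)C3)c(F)c21`: 12700 nM
Compound 2 `CCn1cc(C(=O)Nc2cc([N+](=O)[O-])ccc2F)c(=O)c2cc(F)c(N3CCNC(C)C3)c(F)c21`: 2600 nM

In a functional assay on HCT-116 cells (Homo sapiens) for cytotoxicity, read by MTT assay (a higher number here means a weaker inhibitor, a lower number a stronger inhibitor), compound 2 holds the lower of the two numbers, at 2600 nM. Compound 3 `CCn1cc(C(=O)Nc2ccc(OC(F)(F)F)cc2)c(=O)c2cc(F)c(N3CCNC(C)C3)c(F)c21` has not yet been measured. It carries 4-(trifluoromethoxy)phenyl in place of 2-fluoro-5-nitrophenyl on an amide-type nitrogen. Going by the values given here, one measured step bears on this change, at the same nitrogen: a 4.9-fold lower number from compound 1 to compound 2 (0.69 log units; beyond the scatter). That step is modest. Among the compounds with values here, compound 3 gives up the group gained in a 4.9-fold lower number from compound 1 to compound 2 (0.69 log units; beyond the scatter), so a modest rise in the number is expected in this assay, though no measured compound carries 4-(trifluoromethoxy)phenyl. The estimated step is a 2.1-fold higher number from compound 2 to compound 3 (0.33 log units; beyond the scatter). For compound 3 the expected value is 5500 nM, with an estimated range of 1800 nM to 16000 nM.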

Compound 3, half-maximal inhibitory concentration: 2350 nM
Compound 3: the middle estimate sits 2.3-fold (0.37 log units) above what was measured, and the stated range covers the measured number.
By their numbers in this assay, from the lowest: compounds 3 and 2 (each within the scatter of the next); then compound 1.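

In this assay trifluoromethoxy in place of hydrogen on an aromatic carbon gives a 5.4-fold lower number from compound 1 to compound 3 (0.73 log units; beyond the scatter) and so offers a second substituted aryl group on the amide-type nitrogen that stands apart from the unsubstituted phenyl of compound 1. Exchanging the two substituted aryl groups gives a 1.1-fold lower number from compound 2 to compound 3 (0.04 log units; within the scatter) so that, among these compounds, this position accepts either 2-fluoro-5-nitrophenyl or 4-(trifluoromethoxy)phenyl with no change beyond the scatter. Nothing measured on these groups offers an explanation for either step.

The compounds shown leave open whether the step from phenyl depends on the particular substituents, as the two aryl groups share none. Going by these compounds, it also remains open how a carboxylic acid or an amine on this ring would read, or a longer alkyl chain in place of the aryl group.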